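Acyl cap exchange on a trypsin-assay series

The source may report more compounds than this note shows. Statements on the series, on what has been measured and on what is new or still open speak of the compounds shown alone.

Three peptide-like compounds were measured in an assay on isolated protein for inhibition of Trypsin (Homo sapiens), read by fluorescence, with a stated time of 15 min, tested at 50 uM; on this read-out lower numbers stand for less inhibition and higher numbers for more inhibition at the one concentration tested (going by the name of the read-out). Compound 1 `N=C(N)c1ccc([C@H](NC(=O)c2ccccc2)C(=O)N[C@@H](CCCCN)C(=O)N[C@H](C(N)=O)c2ccccc2)cc1` gives 19.2% in this assay. Compound 2 `N=C(N)Nc1cccc([C@H](NC(=O)c2ccccc2)C(=O)N[C@@H](CCCCN)C(=O)N[C@H](C(N)=O)c2ccccc2)c1` gives 90.8%. Compound 3 `N=C(N)NCCC[C@H](NC(=O)c1ccc(C(F)(F)F)cc1)C(=O)N[C@@H](CCCCN)C(=O)N[C@H](C(N)=O)c1ccccc1` gives 11.5%, the lowest of the three numbers; compound 1 sits within the scatter of it, while compound 2 lies well beyond. Within the data shown here, the one step between compounds differing in a single place, a number 71.6 percentage points higher from compound 1 to compound 2 (beyond the scatter), concerns the amidine-to-guanidine side of the core and not the acyl cap, so it does not bear on the change considered here.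

Compound 4 `N=C(N)NCCC[C@H](NC(=O)CCc1ccccc1)C(=O)N[C@@H](CCCCN)C(=O)N[C@H](C(N)=O)c1ccccc1` is not yet measured. It differs from compound 3 by phenethyl in place of 4-(trifluoromethyl)phenyl on a carbonyl carbon. Among the measured compounds shown here, no measured pair isolates a change at this carbonyl carbon. Compound 1 carries a phenyl on the same carbonyl and compound 3 a 4-(trifluoromethyl)phenyl, and their two values lie within the scatter of each other, but they also differ elsewhere, so nothing firm follows. The author therefore expects no step beyond the scatter, a number 3.5 percentage points higher from compound 3 to compound 4 (within the scatter), and estimates that compound 4 will give 15% in this assay, with a plausible range from 0% to 40%.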

Compound 4, a percentage reported as inhibition, at one concentration (the size of the read-out at that concentration, not a potency): 2.3%
Compound 4: the middle estimate sits 12.7 percentage points above what was measured; measured number inside the range.
By their numbers in this assay, from the lowest: compounds 4, 3 and 1 (each within the scatter of the next, the first and the last beyond it); then compound 2.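

In this assay, among these compounds, phenethyl in place of 4-(trifluoromethyl)phenyl on the carbonyl carbon gives a number 9.2 percentage points lower from compound 3 to compound 4 (within the scatter), and this is the first pair to isolate a change at this position. On the core shared by compound 3 and compound 4, the read-out therefore does not separate these two caps, although one has a trifluoromethyl-bearing aryl group on the carbonyl and the other a phenethyl group, and both numbers are small on this scale. No other measurement bears on this result, so the data give no account of why the two caps read as they do.

From the compounds shown here alone, whether a carboxylic acid or an amine on the cap, or a chain longer than that of phenethyl, would carry the number beyond the scatter on this core remains open. Also open, going by these compounds, is whether the same exchange of caps would read alike on the core of compound 2, which gives 90.8% in this assay, a far higher number than either compound of this pair shows.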